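The source may hold more compounds than are shown below. What is called first, only, known or untested is meant among the compounds shown, and "the series" means these compounds.

Among the measured compounds shown here, compound 2 `c1ccc(-c2ccno2)c(OCC2=NCCN2)c1` is the one compound in this set for which an actual number stands: in a functional assay for activation of Alpha-1D adrenergic receptor (Homo sapiens) (a lower number here means that less compound is needed, a higher number that more compound is needed for the effect), compound 2 gives 100 nM. Compound 1 `c1ccc(-c2ccccc2OCc2c[nH]cn2)cc1` is the other measured compound; in this assay compound 1 gives < 100000 nM, which is a limit of the assay rather than a measured number, so the limit of < 100000 nM in this assay, at which 1 of the 2 values shown sits, is all that can be said of it. For the measured compounds named here, no step between two measured compounds can be drawn from these values. Compound 3 `c1ccc(-c2ccno2)c(OCc2c[nH]cn2)c1` differs from compound 2 in one place: a group of 5 heavy atoms (3 carbon, 2 nitrogen; one five-membered aromatic ring with 2 hetero atoms) in place of a group of 5 heavy atoms (3 carbon, 2 nitrogen; one five-membered non-aromatic ring with 2 hetero atoms), on a saturated chain carbon bound to an oxygen on an aromatic ring, so the non-aromatic ring of compound 2 becomes the aromatic 1H-imidazol-4-yl. Without a measured step to lean on, the expectation is that the change from compound 2 to compound 3 weakens activation beyond the usual scatter, by a 20-fold higher number from compound 2 to compound 3 (1.30 log units; beyond the scatter). Compound 3 is therefore estimated at 2000 nM in this assay, within a range from 300 nM to 15000 nM.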

Compound 3, half-maximal effective concentration: < 100000 nM
Compound 3: a limit, no number; the forecaster's own chance of this, stated with the estimate: 20%; the middle value is on the limit's open side.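

Compound 3 gives < 100000 nM in this assay, a limit of the assay and not a number, so the steps to it from compound 2 and from compound 1 cannot be read. The compounds shown leave open how large either change is, including whether 1,2-oxazol-5-yl in place of phenyl alters activation at all.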